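Trifluoromethyl in place of methyl: note on compound 4

The source may report more compounds than this note shows. Statements on the series, on what has been measured and on what is new or still open speak of the compounds shown alone.

Measured so far in a functional assay on A-375 cells (Homo sapiens) for antiproliferative activity, read by MTT assay, with a stated time of 24 h, tested at 3.7 ug/mL; on this read-out lower numbers stand for a weaker effect and higher numbers for a stronger effect at the one concentration tested:
compound 1 `Cc1ccc2nc(C(=O)Nc3c(F)cc(-c4cccc(F)c4)cc3F)c(C)c(O)c2c1`: 16.2%
compound 2 `Cc1c(C(=O)Nc2c(F)cc(-c3cccc(F)c3)cc2F)nc2ccc(OC(F)(F)F)cc2c1O`: 2.06%
compound 3 `Cc1ccc2nc(C(=O)Nc3c(F)cc(-c4cccc(F)c4)cc3F)c(C)c(C(=O)O)c2c1`: 9.25%

Compound 3 stands second highest of the three numbers; its nearest neighbour is compound 1, which sits higher by an amount within the scatter, and its furthest is compound 2, which sits lower by an amount also within the scatter. The three values therefore spread over a narrow band, and only one of the two single-point steps, a number 14.1 percentage points lower from compound 1 to compound 2 (beyond the scatter), exceeds the scatter; a number 7 percentage points lower from compound 1 to compound 3 (within the scatter) does not.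

Compound 4 `Cc1c(C(=O)Nc2c(F)cc(-c3cccc(F)c3)cc2F)nc2ccc(C(F)(F)F)cc2c1C(=O)O` differs from compound 3 by trifluoromethyl in place of methyl on an aromatic carbon. The step bearing most directly on it is a number 14.1 percentage points lower from compound 1 to compound 2 (beyond the scatter), modest but beyond the scatter, where trifluoromethoxy replaced methyl on an aromatic carbon. For the measured compounds named here, no step with trifluoromethyl itself has been measured, and the carboxy variant of compound 3 has been seen only once, so the transfer of that precedent is uncertain. Going by the values given here, because a number 14.1 percentage points lower from compound 1 to compound 2 (beyond the scatter) is the sole comparable change, a fall in this assay is expected for compound 4, bounded by how low compound 3 already sits. The expected step for compound 4 is a number 6.3 percentage points lower from compound 3 to compound 4 (within the scatter). For compound 4 the estimate in this assay is 3%, with a range from -4% to 11%.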

Compound 4, a percentage reported as inhibition, at one concentration (the size of the read-out at that concentration, not a potency): 27.8%
For compound 4 the middle estimate is 24.8 percentage points below the measured one; measured number above the stated range.
By their numbers in this assay, from the lowest: compounds 2, 3 and 1 (each within the scatter of the next, the first and the last beyond it); then compound 4.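

In this assay the trifluoromethyl change gives a number 18.6 percentage points higher from compound 3 to compound 4 (beyond the scatter), so replacing methyl at this aromatic carbon does not lower the number in every case. The direction is opposite to a number 14.1 percentage points lower from compound 1 to compound 2 (beyond the scatter), where trifluoromethoxy replaced methyl at the same carbon on the hydroxy compound, so the effect of a change here is not fixed across these two pairs, although the entering group and the carboxy or hydroxy partner both differ between the steps and their contributions cannot be separated. No measurement at hand accounts for the rise or for the opposite directions of the two steps.

Going by these compounds, it remains open whether trifluoromethyl gives a similar step on the hydroxy compound, and whether trifluoromethoxy on the carboxy compound moves the number up or down. Also open, on these data alone, is how chlorine, a methoxy group or an amine at this aromatic carbon would compare with methyl, and whether any of these steps would hold at other concentrations, as the read-out here comes from a single concentration.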